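This account rests on a few compounds, and the source may have more. Where it says the series, first, only, none or still open, it means among the compounds named here.

Compound 1 `COc1ccc(-c2noc(CCCCCCC(=O)NO)n2)cc1` gives 3650 nM in a functional assay on U-937 cells (Homo sapiens) for antiproliferative activity, read by MTT assay, with a stated time of 72 h; on this read-out higher numbers stand for weaker inhibition and lower numbers for stronger inhibition. Compound 2 `O=C(CCCCCCc1nc(-c2ccc(C(F)(F)F)cc2)no1)NO` differs from compound 1 by trifluoromethyl in place of methoxy on an aromatic carbon; in this assay compound 2 gives 2870 nM, and the step is a 1.3-fold lower number from compound 1 to compound 2 (0.10 log units; within the scatter). Compound 3 `COc1ccc(-c2noc(CCCCCCC(=O)C(F)(F)F)n2)cc1` differs from compound 1 by trifluoromethyl in place of hydroxyamino on a carbonyl carbon; in this assay compound 3 gives 1170 nM, the step is a 3.1-fold lower number from compound 1 to compound 3 (0.49 log units; beyond the scatter), and compound 3 holds the lowest number of the three, its nearest neighbour being compound 2.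

Compound 4 `O=C(CCCCCCc1nc(-c2ccc(C(F)(F)F)cc2)no1)C(F)(F)F` has not yet been measured. It differs from compound 3 by trifluoromethyl in place of methoxy on an aromatic carbon, so the change from compound 3 to compound 4 is the same change as that from compound 1 to compound 2, this time made on the core of compound 3. On the core of compound 1 that change gave a 1.3-fold lower number from compound 1 to compound 2 (0.10 log units; within the scatter), a step within the scatter. Within the data shown here, no other pair shows how this change behaves on the core of compound 3, so a step of similar size is expected, a 1.2-fold lower number from compound 3 to compound 4 (0.07 log units; within the scatter), resting on the step of a 1.3-fold lower number from compound 1 to compound 2 (0.10 log units; within the scatter) seen between compound 1 and compound 2. Compound 4 is therefore expected to give about 1000 nM, between 550 nM and 1900 nM.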

Compound 4, half-maximal inhibitory concentration: 1960 nM
Compound 4: middle estimate off by 2.0-fold (0.29 log units), on the low side; the whole stated range lies below it.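

In this assay, trifluoromethyl in place of methoxy on an aromatic carbon gives a 1.7-fold higher number from compound 3 to compound 4 (0.22 log units; within the scatter), so this change carries from one core to the other with no difference that can be told from scatter: the same change on two cores in this assay, a 1.3-fold lower number (0.10 log units; within the scatter) from compound 1 to compound 2 and a 1.7-fold higher number (0.22 log units; within the scatter) from compound 3 to compound 4, 2.1-fold (0.33 log units) apart, within the scatter of two such steps. Trifluoromethyl in place of hydroxyamino on a carbonyl carbon gives a 1.5-fold lower number from compound 2 to compound 4 (0.17 log units; within the scatter), and the gap between this step and its earlier counterpart also stays within the scatter: the same change on two cores in this assay, a 3.1-fold lower number (0.49 log units; beyond the scatter) from compound 1 to compound 3 and a 1.5-fold lower number (0.17 log units; within the scatter) from compound 2 to compound 4, 2.1-fold (0.33 log units) apart, within the scatter of two such steps. This does not show that either change behaves identically on both cores, since each rests on a single pair of steps and a dependence on the core smaller than the scatter could be neither seen nor excluded.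

The compounds shown leave open whether this carrying over would hold for other groups on the aromatic carbon, such as chlorine or an amine, or for a carboxylic acid on the carbonyl carbon. They also leave open how the steps would behave with a shorter or longer chain.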